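The source may report more compounds than this note shows. Statements on the series, on what has been measured and on what is new or still open speak of the compounds shown alone.

Of the compounds shown here, three sharing one core have so far been measured in a functional assay on DU-145 cells (Homo sapiens) for cytotoxicity, read by sulforhodamine B assay, with a stated time of 48 h; on this read-out higher numbers stand for weaker inhibition and lower numbers for stronger inhibition. There, compound 1 `C[C@H]1CC[C@@H]2[C@@H](OC(=O)[C@]23CC(c2c(Cl)cccc2Cl)=NO3)[C@]2(C)C(=O)C=C[C@@]12O` gives 38000 nM, compound 2 `COc1ccc(C2=NO[C@]3(C2)C(=O)O[C@@H]2[C@H]3CC[C@H](C)[C@]3(O)C=CC(=O)[C@@]23C)cc1` gives 20000 nM, and compound 3 `C[C@H]1CC[C@@H]2[C@@H](OC(=O)[C@]23CC(c2ccccc2)=NO3)[C@]2(C)C(=O)C=C[C@@]12O` gives 39800 nM. Compound 3, which carries a plain phenyl, cannot be separated from either of the others: the data show a 1.0-fold higher number from compound 1 to compound 3 (0.02 log units; within the scatter) and a 2.0-fold higher number from compound 2 to compound 3 (0.30 log units; within the scatter).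

The next compound, compound 4 `C[C@H]1CC[C@@H]2[C@@H](OC(=O)[C@]23CC(c2ccc([N+](=O)[O-])cc2)=NO3)[C@]2(C)C(=O)C=C[C@@]12O`, differs from compound 3 in one place: nitro in place of hydrogen on an aromatic carbon. In words, this is nitro in place of hydrogen on an aromatic carbon, so phenyl becomes 4-nitrophenyl. Among the measured compounds shown here, no measured compound carries a nitro group, so the evidence is indirect. For the measured compounds named here, the closest precedent is the exchange of hydrogen and methoxy on an aromatic carbon, seen in a 2.0-fold higher number from compound 2 to compound 3 (0.30 log units; within the scatter). The swap of the aryl group itself gives a 1.9-fold lower number from compound 1 to compound 2 (0.28 log units; within the scatter). Neither of these exchanges moved the number beyond the scatter, so no step beyond the scatter is expected in this assay, and no direction can be favoured. The estimated step is a 1.2-fold lower number from compound 3 to compound 4 (0.09 log units; within the scatter). Compound 4 is expected at about 32000 nM, with an estimated range of 14000 nM to 70000 nM.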

Compound 4, half-maximal inhibitory concentration: 7000 nM
For compound 4 the middle estimate is 4.6-fold (0.66 log units) above the measured one; the whole stated range lies above it.
By their numbers in this assay, from the lowest: compound 4; then compounds 2, 1 and 3 (each within the scatter of the next).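

In this assay, changing the aryl group had not so far moved the number beyond the scatter, but nitro in place of hydrogen, on an aromatic carbon para to a large group, gives a 5.7-fold lower number from compound 3 to compound 4 (0.75 log units; beyond the scatter). The 4-nitrophenyl group also stands apart from the 4-methoxyphenyl and 2,6-dichlorophenyl groups, with a 2.9-fold lower number from compound 2 to compound 4 (0.46 log units; beyond the scatter) and a 5.4-fold lower number from compound 1 to compound 4 (0.73 log units; beyond the scatter), which shows that this position of the shared core can change the read-out and that the change here is towards stronger inhibition. The data shown include no separate measurement that could account for this step.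

The compounds shown leave open whether the step is particular to nitro or whether a nitrile, a carboxylic acid or an amine on the same aromatic carbon would give a similar number. They also leave open whether nitro on a different carbon of the six-membered ring would match the result for 4-nitrophenyl.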